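A few compounds are considered here, and "the series" means these few. Any claim that something is new, unique, unknown or untested is made for them only; others in the source may bear on it.

Compound 1 `COc1ccc(CNc2nc3cc(N)cc(N)c3nc2-c2ccccc2)cc1OC` in a functional assay on OVCAR-3 cells (Homo sapiens) for inhibition, read by sulforhodamine B assay, with a stated time of 48 h; on this read-out higher numbers stand for lower toxicity in this test and lower numbers for higher toxicity in this test: 8510 nM
Compound 2 `Nc1cc(N)c2nc(-c3ccccc3)c(NCc3ccc(F)cc3)nc2c1` in this assay : a limit, < 100000 nM

For compound 2 this assay gives only a limit and no number, as the limit of < 100000 nM in this assay, at which 1 of the 2 values shown sits, records. The step that the limit leaves unreadable from compound 1 to compound 2 therefore cannot be sized. Compound 3 `Nc1cc(N)c2nc(-c3ccccc3)c(Sc3ccc(F)cc3)nc2c1` differs from compound 2 by (4-fluorophenyl)sulfanyl in place of (4-fluorobenzyl)amino on an aromatic carbon. Among the measured compounds shown here, no measured step covers this change, and the single step that involves compound 2 is unreadable, so the expectation leans on compound 1 alone with a wide range. Compound 3 is expected near 20000 nM, between 3000 nM and 100000 nM. This estimate means an expected step that the limit leaves unreadable from compound 2 to compound 3.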

Compound 3, concentration lethal to 50% of the cells: 69200 nM
Compound 3: middle estimate off by 3.5-fold (0.54 log units), on the low side; the measured number falls inside the stated range.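

In this assay compound 2 has only a limit, so no new step can be read between compound 2 and compound 3. The compounds shown leave open how far (4-fluorophenyl)sulfanyl in place of (4-fluorobenzyl)amino shifts the read-out.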